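The compounds below may be only part of what the source reports. "The series", "measured", "known", "first", "only" and "open" are said of these compounds alone.

Measured compounds:
- compound 1, `CSc1nc2c(N)ncnc2n1[C@@H]1O[C@H](COP(=O)(O)OP(=O)(O)OP(=O)(O)O)[C@@H](O)[C@H]1O`, in an assay on isolated protein (strain Sprague-Dawley) for inhibition of adenylate kinase isoenzyme 1 (Rattus norvegicus), using Lineweaver-Burk analysis (a higher number here means a weaker inhibitor, a lower number a stronger inhibitor), compound 1 gives 5950000 nM
- compound 2, `CCCSc1nc2c(N)ncnc2n1[C@@H]1O[C@H](COP(=O)(O)OP(=O)(O)OP(=O)(O)O)[C@@H](O)[C@H]1O`, in this assay compound 2 gives 6150000 nM

Compound 2 and compound 1 give numbers that sit within the scatter of each other, so the two cannot be told apart in this assay on the data at hand. Compound 3, `CCCCSc1nc2c(N)ncnc2n1[C@@H]1O[C@H](COP(=O)(O)OP(=O)(O)OP(=O)(O)O)[C@@H](O)[C@H]1O`, differs from compound 2 by methyl in place of hydrogen on a saturated chain carbon, three bonds along the chain from a sulfur. Among the measured compounds shown here, the one measured step that bears on this change is the earlier lengthening of the same chain, a 1.0-fold higher number from compound 1 to compound 2 (0.01 log units; within the scatter), which left the number essentially unchanged. Since that step stayed within the scatter, compound 3 is expected to behave like compound 2, with a step of a 1.0-fold higher number from compound 2 to compound 3 (0.00 log units; within the scatter) that is not beyond the scatter. Compound 3 is therefore estimated to give 6200000 nM in this assay, in a range from 3100000 nM to 12400000 nM.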

Compound 3, half-maximal inhibitory concentration: 6200000 nM
For compound 3 middle estimate and measured number coincide at the digits printed, and the stated range covers the measured number.
By their numbers in this assay, from the lowest: compounds 1, 2 and 3 (each within the scatter of the next).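

In this assay, methyl in place of hydrogen on a saturated chain carbon, three bonds along the chain from a sulfur, gives a 1.0-fold higher number from compound 2 to compound 3 (0.00 log units; within the scatter) and so adds a second lengthening of this chain that stays within the scatter. Among the compounds shown here, the earlier compounds showed only one such step, whereas the two ends of the series can now be set side by side: the full lengthening of the chain gives a 1.0-fold higher number from compound 1 to compound 3 (0.02 log units; within the scatter) and leaves these two compounds indistinguishable as well. Nothing at hand accounts for this flat reading.

All three compounds carry plain saturated chains on the sulfur. The compounds shown leave open whether a longer chain such as octyl, a benzyl group, or a chain ending in an amine or a carboxylic acid would read any differently.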